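Methylcarbamoyl in place of methoxy on a shared core

This account rests on a few compounds, and the source may have more. Where it says the series, first, only, none or still open, it means among the compounds named here.

Compound 1, `Fc1cc2[nH]ncc2cc1-c1ccccc1C(F)(F)F`: 48 nM
Compound 2, `CC(C)c1cc2[nH]ncc2cc1-c1ccccc1C(F)(F)F`: 25400 nM
Compound 3, `COc1cc2[nH]ncc2cc1-c1ccccc1C(F)(F)F`: 26 nM

Three compounds share one core and differ only in a single group on an aromatic carbon. In an assay on CHO-TREX cells for antagonist activity at transient receptor potential cation channel subfamily A member 1 (Homo sapiens), read by FLIPR and calcium flux, with a stated time of 10 min (on this read-out higher numbers stand for weaker inhibition and lower numbers for stronger inhibition), compound 3 gives the lowest number of the three. Compound 1 sits close to it, since the step of a 1.8-fold lower number from compound 1 to compound 3 (0.27 log units; within the scatter) lies within the scatter, so these two cannot be ranked against each other. Compound 2 stands far away, as the step of a 980-fold lower number from compound 2 to compound 3 (2.99 log units; beyond the scatter) shows.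

Compound 4, `CNC(=O)c1cc2[nH]ncc2cc1-c1ccccc1C(F)(F)F`, has not yet been measured. It arises from compound 3 by one change: methylcarbamoyl in place of methoxy on an aromatic carbon. Among the measured compounds shown here, two measured steps bear on this. The step of a 1.8-fold lower number from compound 1 to compound 3 (0.27 log units; within the scatter) shows that a small exchange at the same place passes unnoticed, whereas a 980-fold lower number from compound 2 to compound 3 (2.99 log units; beyond the scatter) shows that another exchange there can move the number enormously. For the measured compounds named here, the entering group carries more heavy atoms than the leaving one and adds a hydrogen-bond donor, and no measured compound holds such a group, so the outcome is uncertain, with a loss judged more likely than a gain. Compound 4 is therefore expected to give about 1000 nM in this assay, with a range from 100 nM to 12000 nM. That estimate means a step of a 38-fold higher number from compound 3 to compound 4 (1.59 log units; beyond the scatter), expected rather than known.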

Compound 4, half-maximal inhibitory concentration: > 30000 nM
Compound 4: only a limit was reported; the forecaster's own chance of this, stated with the estimate: 10%; at least 30-fold (1.47 log units) between middle value and limit.
By their numbers in this assay, from the lowest: compounds 3 and 1 (each within the scatter of the next); then compound 2. At a limit, above all of these: compound 4.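

The reading for compound 4 is a limit of the assay and not a number: the limit of > 30000 nM in this assay, at which 1 of the 4 values shown sits. Even so, the position that accepts both fluoro and methoxy does not accept methylcarbamoyl, as an at least 1100-fold higher number from compound 3 to compound 4 (3.06 log units; beyond the scatter) and an at least 620-fold higher number from compound 1 to compound 4 (2.79 log units; beyond the scatter) show, so isopropyl is no longer the only group here that brings a large loss. Against isopropyl itself the data give only an at least 1.1-fold higher number from compound 2 to compound 4 (0.07 log units; that floor lies within the scatter), so compound 2 and compound 4 cannot be ranked against each other.

The compounds shown do not separate the hydrogen-bond donor that methylcarbamoyl adds from its extra heavy atoms, so no cause for the loss can be named. They also leave open how a nitrile, a chloro group or a dimethylcarbamoyl group would fare at this position.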